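Aminothiazole ketones: fluoro to methyl on the anilino ring

This account rests on a few compounds, and the source may have more. Where it says the series, first, only, none or still open, it means among the compounds named here.

Measured in a functional assay on MOLT-4 cells (Homo sapiens) for antiproliferative activity, read by cell counting, with a stated time of 2 days; a lower number here means a stronger inhibitor, a higher number a weaker inhibitor:
- compound 1 `COc1cc(C(=O)c2sc(Nc3ccc(F)cc3)nc2N)cc(OC)c1OC` gives 280 nM
- compound 2 `COc1cc(C(=O)c2sc(Nc3ccc(C)cc3)nc2N)cc(OC)c1OC` gives 21 nM
- compound 3 `Nc1nc(Nc2ccc(F)cc2)sc1C(=O)c1ccccc1` gives only > 10000 nM, a limit of this assay

Compound 1 and compound 2 share one core and differ by methyl in place of fluoro on an aromatic carbon. That change made a 13-fold lower number from compound 1 to compound 2 (1.12 log units; beyond the scatter) in this assay. Compound 3 carries a different core; the difference between the two cores is not broken down here. For compound 3 this assay gives a limit and no number, (the limit of > 10000 nM in this assay, at which 1 of the 3 values shown sits).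

Compound 4 `Cc1ccc(Nc2nc(N)c(C(=O)c3ccccc3)s2)cc1`, not yet measured, differs from compound 3 by methyl in place of fluoro on an aromatic carbon, the same change as from compound 1 to compound 2, made at a place described in the same words.

Expectation for compound 4 in this assay: a step like an at least 3.3-fold lower number from compound 3 to compound 4 (0.52 log units; beyond the scatter), resting on the single earlier step of a 13-fold lower number from compound 1 to compound 2 (1.12 log units; beyond the scatter) and on the limit of compound 3, > 10000 nM, which leaves the starting point open. Compound 4 is therefore estimated at 3000 nM, between 500 nM and 20000 nM, with a real chance that only a limit is returned again.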

Compound 4, half-maximal inhibitory concentration: 210 nM
Beside the measured number, compound 4's estimate is 14-fold (1.15 log units) above it; measured number outside the range, below it.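

Notes on carrying the change: in this assay, methyl in place of fluoro lowers the number again on the second core, with an at least 47-fold lower number from compound 3 to compound 4 (1.67 log units; beyond the scatter), so the direction of the step carries from the core of compound 1 to the core of compound 3, while its size does not match: the same change on two cores in this assay, a 13-fold lower number (1.12 log units; beyond the scatter) from compound 1 to compound 2 and an at least 47-fold lower number (1.67 log units; beyond the scatter) from compound 3 to compound 4, at least 3.5-fold (0.55 log units) apart, beyond the scatter of two such steps
As far as these compounds go, for compound 3, > 10000 nM is a limit of the assay and not a number, so the full size of the step on this core stays unknown, and the gap between the two steps may be wider than printed.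
Two cores and one pair on each show agreement in direction for these compounds only and give no rule for other cores.

Only fluoro and methyl are shown on the aromatic carbon para to a large group, so the standing of chloro, an amine or a longer chain there remains open. From the compounds shown here alone, whether the step keeps its direction on any further core, or in any other read-out, also remains open.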